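This account rests on a few compounds, and the source may have more. Where it says the series, first, only, none or still open, it means among the compounds named here.

The measured compounds:
- compound 1, `NC(=O)c1c(NC(=O)c2ccccc2Cl)sc2c1CCNC2`: in a functional assay on HL-60 cells (Homo sapiens) for antiproliferative activity, with a stated time of 24 h (a lower number here means a stronger inhibitor, a higher number a weaker inhibitor), compound 1 gives 18600 nM
- compound 2, `NC(=O)c1c(NC(=O)c2ccccc2Cl)sc2c1CCN(Cc1ccc(Cl)cc1)C2`: in this assay compound 2 gives 22500 nM
- compound 3, `NC(=O)c1c(NC(=O)c2ccccc2Cl)sc2c1CCN(Cc1c(Cl)cccc1Cl)C2`: in this assay compound 3 gives 4850 nM

Compound 3 holds the lowest number of the three, and both steps leading to it lie beyond the scatter: a 3.8-fold lower number from compound 1 to compound 3 (0.58 log units; beyond the scatter) and a 4.6-fold lower number from compound 2 to compound 3 (0.67 log units; beyond the scatter). The step of a 1.2-fold higher number from compound 1 to compound 2 (0.08 log units; within the scatter) lies within the scatter. All three measured steps change only the group on the amine nitrogen in the ring; the group on the carbonyl carbon stays as 2-chlorophenyl throughout. Compound 4, `NC(=O)c1c(NC(=O)c2cccc([N+](=O)[O-])c2)sc2c1CCN(Cc1c(Cl)cccc1Cl)C2`, keeps the 2,6-dichlorobenzyl of compound 3 and alters that untouched part: 3-nitrophenyl in place of 2-chlorophenyl on a carbonyl carbon. Among the measured compounds shown here, no measured step bears on this change; nothing among the measured compounds shows what replacing the group on the carbonyl carbon does. The expectation rests on compound 3 alone, and the step of a 1.1-fold higher number from compound 3 to compound 4 (0.05 log units; within the scatter) is estimated with a wide range. For compound 4 the estimated value in this assay is 5500 nM, expected to fall between 1500 nM and 20000 nM.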

Compound 4, half-maximal inhibitory concentration: 18400 nM
Estimate against measurement, compound 4: 3.3-fold (0.52 log units) below; low and high end bracket the measured number.
By their numbers in this assay, from the lowest: compound 3; then compounds 4, 1 and 2 (each within the scatter of the next).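

Among the compounds shown here, the group on the carbonyl carbon, left unchanged in the earlier compounds, clearly affects the result: in this assay, 3-nitrophenyl in place of 2-chlorophenyl gives a 3.8-fold higher number from compound 3 to compound 4 (0.58 log units; beyond the scatter). This step is the same size as the gain from the 2,6-dichlorobenzyl on the amine nitrogen, a 3.8-fold lower number from compound 1 to compound 3 (0.58 log units; beyond the scatter), but it runs in the opposite direction, towards a weaker inhibitor. No measurement shown here explains the rise, so its cause remains unknown.

For the compounds shown here, with only two groups compared at this position, it remains unclear whether the loss of 2-chlorophenyl or the arrival of 3-nitrophenyl matters more, and a plain phenyl or an aminophenyl on the carbonyl carbon would help separate the two. Going by these compounds, it is also open whether this change would act the same way with hydrogen or 4-chlorobenzyl on the amine nitrogen.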